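The source may hold more compounds than are shown below. What is called first, only, known or untested is meant among the compounds shown, and "the series" means these compounds.

Working notes on the series. In a functional assay on Ehrlich cells (Mus musculus) for cytotoxicity, tested at 100 ug/mL (on this read-out lower numbers stand for a weaker effect and higher numbers for a stronger effect at the one concentration tested), compound 3 `COc1cc(N2C(N)=C(C#N)C(c3ccc(C)cc3)C3=C2CC(C)(C)CC3=O)cc(OC)c1OC` gives 90%. Of the three numbers in hand it stands near the top together with compound 1 `COc1ccccc1C1C(C#N)=C(N)N(c2cc(OC)c(OC)c(OC)c2)C2=C1C(=O)CC(C)(C)C2`, which in this assay gives 100%; the step of a number 10 percentage points lower from compound 1 to compound 3 (within the scatter) is within the scatter, so the two are not separated. The far end is compound 2 `COc1cc(N2C(N)=C(C#N)C(c3ccccc3Cl)C3=C2CC(C)(C)CC3=O)cc(OC)c1OC`, which gives 20%, and the step of a number 70 percentage points higher from compound 2 to compound 3 (beyond the scatter) is large and beyond the scatter.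

The next compound, compound 4 `COc1cc(N2C(N)=C(C#N)C(c3ccccc3)C3=C2CC(C)(C)CC3=O)cc(OC)c1OC`, differs from compound 3 in one place: hydrogen in place of methyl on an aromatic carbon. Among the measured compounds shown here, no measured step removes a methyl group; the two steps that reach compound 3 both swap the whole aryl ring, and they were a number 10 percentage points lower from compound 1 to compound 3 (within the scatter) and a number 70 percentage points higher from compound 2 to compound 3 (beyond the scatter), so the aryl ring clearly matters, but the change here removes one heavy atom only, leaving the ring in place. The expected step is therefore a number 5 percentage points lower from compound 3 to compound 4 (within the scatter), not beyond the scatter. Compound 4 is estimated at 85% in this assay, with a range from 55% to 100%.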

Compound 4, a percentage reported as activity, at one concentration (the size of the read-out at that concentration, not a potency): 10%
For compound 4 the middle estimate is 75 percentage points above the measured one, and the stated range ends above it.
By their numbers in this assay, from the lowest: compounds 4 and 2 (each within the scatter of the next); then compounds 3 and 1 (each within the scatter of the next).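

Removing one methyl from the aromatic carbon para to a large group, the change from 4-methylphenyl to phenyl, is enough on its own to give a number 80 percentage points lower from compound 3 to compound 4 (beyond the scatter) in this assay, so this position is far more sensitive than its single heavy atom suggested. Hydrogen in place of chloro gives a number 10 percentage points lower from compound 2 to compound 4 (within the scatter), while hydrogen in place of methoxy gives a number 90 percentage points lower from compound 1 to compound 4 (beyond the scatter), which places the unsubstituted phenyl ring with the chloro compound and apart from the methoxy and methyl compounds. Nothing at hand explains why this one methyl matters so much.

Going by these compounds, whether the effect is specific to methyl stays open, since an ethyl, a methoxy or an amine on that same aromatic carbon would show if other groups there give the high read-out. On these data alone, the read-out also comes from one concentration, so how compounds 1 and 3 differ in potency stays open too.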